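The compounds below may be only part of what the source reports. "The series", "measured", "known", "first", "only" and "open" are said of these compounds alone.

Measured so far in a functional assay on HeLa cells (Homo sapiens) for antiproliferative activity, read by sulforhodamine B assay, with a stated time of 48 h; on this read-out higher numbers stand for weaker inhibition of growth and lower numbers for stronger inhibition of growth
- compound 1 `Sc1nnc(C2=C(Cl)c3ccccc3CCC2)n1-c1ccccc1` gives 5500 nM
- compound 2 `S=c1[nH]nc(C2=C(Cl)c3ccccc3CCC2)o1` gives 981 nM
- compound 3 `ClC1=C(c2nnc(-c3ccccc3)o2)CCCc2ccccc21` gives 3220 nM

Compound 3 lies within the usual scatter of compound 1, and its number is higher than that of compound 2 by a margin beyond the scatter. Compound 4 `O=[N+]([O-])c1ccc(-c2nnc(C3=C(Cl)c4ccccc4CCC3)o2)cc1` differs from compound 3 by nitro in place of hydrogen on an aromatic carbon, para to a large group (nitro in place of hydrogen on an aromatic carbon). Going by the values given here, no measured pair tests this change, so the expectation rests on compound 3 (3220 nM), and no step beyond the scatter is expected in this assay. The expected change a 1.3-fold lower number from compound 3 to compound 4 (0.11 log units; within the scatter) is small. For compound 4 the estimated value is 2500 nM (expected range 800 nM to 7500 nM).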

Compound 4, concentration for 50% growth inhibition: 1320 nM
The estimate for compound 4 lay 1.9-fold (0.28 log units) above the measured number; the range from low to high includes it.
By their numbers in this assay, from the lowest: compounds 2 and 4 (each within the scatter of the next); then compounds 3 and 1 (each within the scatter of the next).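

In this assay, going by these compounds alone, nitro in place of hydrogen on an aromatic carbon, para to a large group, gives a 2.4-fold lower number from compound 3 to compound 4 (0.39 log units; beyond the scatter) as the first step between compounds that differ in one place. Within the data shown here, this shows that the position responds to substitution, which the earlier compounds could not show, although the step is modest. Nothing at hand gives a reason for the step.

As far as these compounds go, whether an amine or a methoxy group at this position would move the number in the same direction stays open. Also open, from the compounds shown here alone, is whether nitro would give a similar step at another position on this ring.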